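The source may report more compounds than this note shows. Statements on the series, on what has been measured and on what is new or still open speak of the compounds shown alone.

Measured so far in a functional assay on HT-29 cells (Homo sapiens) for cytotoxicity, read by MTT assay, with a stated time of 72 h; a lower number here means a stronger inhibitor, a higher number a weaker inhibitor
- compound 1 (`O=C(CN1CCN(c2nnc(Cc3ccccc3)c3ccccc23)CC1)Nc1c(F)cccc1F`) at 19700 nM
- compound 2 (`Cc1ccc(NC(=O)CN2CCN(c3nnc(Cc4ccncc4)c4ccccc34)CC2)c(C)c1`) at 1930 nM

Compound 1 stands at the high end of these two numbers, and compound 2 lies lower by a margin beyond the scatter. Among the measured compounds shown here, no single-change step between measured compounds is available, so the expectation below is only loosely anchored.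

Next in line is compound 3 (`O=C(CN1CCN(c2nnc(Cc3ccccc3)c3ccccc23)CC1)Nc1ccc(F)c(C(F)(F)F)c1`). The change from compound 1 is 4-fluoro-3-(trifluoromethyl)phenyl in place of 2,6-difluorophenyl on an amide-type nitrogen with 4-fluoro-3-(trifluoromethyl)phenyl in place of 2,6-difluorophenyl on an amide-type nitrogen.

In this assay a move toward a lower number is expected, since compound 1 already holds the higher of the two values (19700 nM). The estimated move is a 3.3-fold lower number from compound 1 to compound 3 (0.52 log units; beyond the scatter) and may not clear the scatter by much. For compound 3 the expected value is 6000 nM within an estimated range of 1500 nM to 20000 nM (expectation only).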

Compound 3, half-maximal inhibitory concentration: 4590 nM
For compound 3 the middle estimate is 1.3-fold (0.12 log units) above the measured one; the range from low to high includes it.
By their numbers in this assay, from the lowest: compound 2; then compound 3; then compound 1.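

With the rest of the structure held constant, the group on the amide-type nitrogen proves able to shift the number in this assay: 4-fluoro-3-(trifluoromethyl)phenyl in place of 2,6-difluorophenyl gives a 4.3-fold lower number from compound 1 to compound 3 (0.63 log units; beyond the scatter). The earlier compounds shown here could not show this, as they differ in more than one place. Nothing available accounts for the size or direction of this step.

From the compounds shown here alone, how much of the step belongs to the trifluoromethyl group and how much to the changed placing of fluorine remains open, as both change together in this single step. Also open, going by these compounds, is how a plain phenyl, or a phenyl carrying a methoxy group or a nitrile, would read on this same nitrogen.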